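Swapping the nitrophenyl arm of compound 1 for a chlorophenyl

The compounds below may be only part of what the source reports. "The series", "measured", "known", "first", "only" and "open" are said of these compounds alone.

Compound 1, `O=C1C(O)=C(C(c2cccc([N+](=O)[O-])c2)c2c[nH]c3ccccc23)C(=O)c2ccccc21`, was tested in a toxicity assay (Homo sapiens) for cytotoxicity, read by MTT assay, with a stated time of 48 h (on this read-out lower numbers stand for stronger inhibition and higher numbers for weaker inhibition), and gave 91200 nM, the highest of the two numbers recorded so far. Among the compounds with values here, its one measured neighbour is compound 2, `O=C1C(O)=C(C(c2cccc([N+](=O)[O-])c2)c2c(-c3ccccc3)[nH]c3ccccc23)C(=O)c2ccccc21`, which in this assay gave 13400 nM; that step, a 6.8-fold lower number from compound 1 to compound 2 (0.83 log units; beyond the scatter), came from a phenyl in place of hydrogen on an aromatic carbon of the shared core. Compound 3, `O=C1C(O)=C(C(c2ccc(Cl)cc2)c2c[nH]c3ccccc23)C(=O)c2ccccc21`, is not yet measured. It differs from compound 1 in a different place: 4-chlorophenyl in place of 3-nitrophenyl on a saturated chain carbon bound to an aromatic carbon and a double-bonded ring carbon. Within the data shown here, no measured step touches that position, so the only step available, the one from compound 1 to compound 2, does not bear on this change, and nothing in the data shows how exchanging one six-membered aromatic ring for another on the saturated chain carbon shifts the number. The cautious expectation is therefore no step beyond the scatter, with compound 3 estimated at 80000 nM, within a range of 25000 nM to 250000 nM, which amounts to an expected step of a 1.1-fold lower number from compound 1 to compound 3 (0.06 log units; within the scatter).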

Compound 3, half-maximal inhibitory concentration: 102000 nM
Compound 3: the middle estimate sits 1.3-fold (0.11 log units) below what was measured; measured number inside the range.
By their numbers in this assay, from the lowest: compound 2; then compounds 1 and 3 (each within the scatter of the next).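

In this assay, within the data shown here, the exchange of 3-nitrophenyl for 4-chlorophenyl on the saturated chain carbon gave a 1.1-fold higher number from compound 1 to compound 3 (0.05 log units; within the scatter) and so left the number in place, whereas the only earlier change, a phenyl on an aromatic carbon of the shared core, gave a 6.8-fold lower number from compound 1 to compound 2 (0.83 log units; beyond the scatter) and moved it beyond the scatter. The leaving arm counts 2 hydrogen-bond acceptors and the entering arm 0, so in this one pair, losing those acceptors and swapping nitro for chlorine on the six-membered aromatic ring comes with no step beyond the scatter. Nothing available gives a reason for this flat result.

With only these two aromatic arms shown at this position, it remains open whether something quite different there, such as an amine, a carboxylic acid or a longer alkyl chain, would shift the number. Also open, as far as these compounds go, is whether 4-chlorophenyl on the saturated chain carbon, combined with the phenyl on the aromatic carbon, would lower the number in the way that phenyl did for compound 2.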